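A few compounds are considered here, and "the series" means these few. Any claim that something is new, unique, unknown or untested is made for them only; others in the source may bear on it.

Compound 2 `Cc1cccc(/C(N)=N/NC(=S)N2CCOCC2)n1` sits at the top of the two numbers gathered so far: in a functional assay on A-431 cells (Homo sapiens) for cytotoxicity, read by MTT assay, with a stated time of 72 h, tested at 10 uM (on this read-out lower numbers stand for less inhibition of growth and higher numbers for more inhibition of growth at the one concentration tested), compound 2 gives 68.1%, whereas compound 1 `Cc1cccc(/C(N)=N/NC(=S)N2CCSCC2)n1` gives 53.2% in this assay. Within the data shown here, the one measured step, a number 14.9 percentage points higher from compound 1 to compound 2 (beyond the scatter), exchanges one six-membered ring for another on the thiocarbonyl carbon and lies beyond the scatter. Compound 3 `Cc1cccc(/C(N)=N/NC(=S)N2CCCCC2)n1` carries on at that same edge of the molecule: piperidin-1-yl in place of morpholin-4-yl on a thiocarbonyl carbon. The measured step bears on this only loosely, since it altered the same ring at the same place but swapped one hetero atom for another rather than removing one, and it was modest in size. A step of comparable size in either direction, or none beyond the scatter, would therefore be no surprise. The step from compound 2 to compound 3 is expected to be a number 10.1 percentage points lower from compound 2 to compound 3 (beyond the scatter). Compound 3 is accordingly estimated at 58%, with a range from 40% to 76%.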

Compound 3, percent growth inhibition at one concentration: 47.8%
Beside the measured number, compound 3's estimate is 10.2 percentage points above it; measured number inside the range.
By their numbers in this assay, from the lowest: compounds 3 and 1 (each within the scatter of the next); then compound 2.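

Piperidin-1-yl in place of morpholin-4-yl on a thiocarbonyl carbon gives a number 20.3 percentage points lower from compound 2 to compound 3 (beyond the scatter) in this assay, a step that lies beyond the scatter and is larger than the first one measured at this position. The second new step, a number 5.4 percentage points lower from compound 1 to compound 3 (within the scatter), shows that piperidin-1-yl and thiomorpholin-4-yl cannot be told apart here, so among these three compounds only morpholin-4-yl, in compound 2, stands apart from the other two rings. Nothing measured here accounts for why that ring differs from the other two.

On these data alone, it remains open whether piperazin-1-yl, with a second ring nitrogen, would match compound 2 or fall with compound 1 and compound 3. Equally open, as far as these compounds go, is how the smaller pyrrolidin-1-yl ring or an open-chain dimethylamino group would read at this position.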